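Swapping methyl for chloro in a sulfonamide series

The compounds below may be only part of what the source reports. "The series", "measured", "known", "first", "only" and "open" are said of these compounds alone.

Four sulfonamides are compared here. Compound 1 `Cc1ccc(S(=O)(=O)Nc2cccc([N+](=O)[O-])c2)cc1` and compound 2 `O=[N+]([O-])c1cccc(NS(=O)(=O)c2ccc(Cl)cc2)c1` share one core; compound 3 `Cc1ccc(S(=O)(=O)Nc2ccc(Cl)cc2)cc1` and compound 4 `O=S(=O)(Nc1ccc(Cl)cc1)c1ccc(Cl)cc1` share another. How the two cores differ is not broken down here.

In an ADME assay, compound 1 gives 8.27, compound 2 gives 7.51 and compound 3 gives 9.02, the highest of the three. The change from compound 1 to compound 2 is chloro in place of methyl on an aromatic carbon; its effect was a number 0.76 log units lower from compound 1 to compound 2 (beyond the scatter).

Compound 4 has not yet been measured in this assay. For the measured compounds named here, it differs from compound 3 by chloro in place of methyl on an aromatic carbon, the same change as the one between compound 1 and compound 2, made at the same kind of place. Going by the values given here, the only guide is that single earlier step, so the expectation rests on the assumption that it repeats: the estimated step is a number 0.76 log units lower from compound 3 to compound 4 (beyond the scatter). On that basis compound 4 is expected to give about 8.26 in this assay, most likely between 7.9 and 8.6. The measurement will show whether that holds.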

Compound 4, acid dissociation constant: 8.3
For compound 4 the middle estimate is 0.04 log units below the measured one; measured number inside the range.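

In this assay, the swap of chloro for methyl on an aromatic carbon, para to a large group, gives a number 0.72 log units lower from compound 3 to compound 4 (beyond the scatter), so the change made on the core of compound 1 has a closely matching counterpart on the core of compound 3. The two steps can be set side by side, and they agree: the same change on two cores in this assay, a number 0.76 log units lower (beyond the scatter) from compound 1 to compound 2 and a number 0.72 log units lower (beyond the scatter) from compound 3 to compound 4, 0.04 log units apart, within the scatter of two such steps.

For the compounds shown here, this supports carrying the swap between these two cores, where its size stayed the same within the scatter, but it rests on only two pairs of compounds. It does not show that the step would hold on any other core, and it gives no reason why the number moves as it does.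

Still open, going by these compounds, is whether bromo, nitrile or trifluoromethyl in the same place would give a step of similar size. Also open, on these data alone, is whether the chloro-for-methyl step would stay the same on a core carrying an amine or a carboxylic acid.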